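The source may hold more compounds than are shown below. What is called first, only, known or untested is meant among the compounds shown, and "the series" means these compounds.

Measured so far in a physicochemical assay for lipophilicity, measured as octanol-water partition, at pH 7.4; on this read-out lower numbers stand for lower lipophilicity and higher numbers for higher lipophilicity:
- Compound 1 (`CC(=O)N[C@H](C(=O)N1C[C@H](O)C[C@H]1C(=O)N[C@@H](CCc1ccc(Br)cc1)c1ccc(-c2scnc2C)cc1)C(C)(C)C`): 4.08
- Compound 2 (`CCOC(=O)CC[C@H](NC(=O)[C@@H]1C[C@@H](O)CN1C(=O)[C@@H](NC(C)=O)C(C)(C)C)c1ccc(-c2scnc2C)cc1`): 1.59

Of these two, compound 2 stands lower, at 1.59. Compound 3 (`CC(=O)N[C@H](C(=O)N1C[C@H](O)C[C@H]1C(=O)N[C@@H](CCc1ccncc1)c1ccc(-c2scnc2C)cc1)C(C)(C)C`) has not yet been measured. It differs from compound 2 as follows: pyridin-4-yl in place of ethoxycarbonyl on a saturated chain carbon, three bonds along the chain from an amide-type nitrogen and an aromatic carbon. That is, pyridin-4-yl sits in place of ethoxycarbonyl on a saturated chain carbon, three bonds along the chain from an amide-type nitrogen and an aromatic carbon.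

Going by the values given here, only one measured step bears on this place: a number 2.49 log units lower from compound 1 to compound 2 (beyond the scatter), a large one. Compound 3 again carries a six-membered aromatic ring there, as the 4-bromophenyl of compound 1 does, but without the bromine, so only a small part of that step is expected to return in this assay. The expected change is a number 0.51 log units higher from compound 2 to compound 3 (beyond the scatter). The estimate for compound 3 is 2.1, with an expected range of 1.5 to 2.8.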

Compound 3, distribution coefficient: 2.7
Beside the measured number, compound 3's estimate is 0.60 log units below it; the measured number falls inside the stated range.
By their numbers in this assay, from the lowest: compound 2; then compound 3; then compound 1.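

In this assay the pyridin-4-yl group gives a number 1.11 log units higher from compound 2 to compound 3 (beyond the scatter) and, set against the 4-bromophenyl group, a number 1.38 log units lower from compound 1 to compound 3 (beyond the scatter) at this saturated chain carbon. The position therefore separates all three groups, and the two six-membered aromatic rings do not give the same number, so carrying such a ring there does not alone set the read-out. Nothing measured here accounts for these differences. The compounds shown leave open where a plain phenyl would fall, with neither the bromine nor the ring nitrogen, and what a carboxylic acid in place of the ethyl ester would give.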